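Isopropyl in place of dimethoxypropyl on the ring nitrogen

This account rests on a few compounds, and the source may have more. Where it says the series, first, only, none or still open, it means among the compounds named here.

Three measured compounds share a core. Compound 1 `COC(CCn1cnc2c(NCc3ccc(C(=O)Nc4ccccc4N)cc3)nc(Cl)nc21)OC` gives 51.2% in a functional assay on NCI-H460 cells (Homo sapiens) for antiproliferative activity, read by CCK-8 assay, with a stated time of 72 h, tested at 8 uM; a lower number here means a weaker effect, a higher number a stronger effect of the compound at the concentration tested. Compound 2 `Cc1ccc(Nc2nc(Cl)nc3c2ncn3Cc2ccc(C(=O)Nc3ccccc3N)cc2)cc1` gives 82.5% in this assay, a number beyond the scatter from that of compound 1 and the highest of the three. Compound 3 `Nc1ccccc1NC(=O)/C=C/c1ccc(COCNc2nc(Nc3cccc(Cl)c3)c3ncn(C4CCCC4)c3n2)cc1` gives 46.1% in this assay, which lies within the scatter of compound 1, so the two cannot be set apart. Compound 4 `CC(C)n1cnc2c(NCc3ccc(C(=O)Nc4ccccc4N)cc3)nc(Cl)nc21` is not yet measured in this assay. It differs from compound 1 in one place: isopropyl in place of 3,3-dimethoxypropyl on an aromatic nitrogen. For the measured compounds named here, no measured pair shows this change, so there is no precedent for its effect; the expected step from compound 1 to compound 4 is none beyond the scatter, a number 3.8 percentage points higher from compound 1 to compound 4 (within the scatter). Compound 4 is therefore estimated at 55%, between 35% and 75%.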

Compound 4, a percentage reported as inhibition, at one concentration (the size of the read-out at that concentration, not a potency): 80.5%
Compound 4: the middle estimate sits 25.5 percentage points below what was measured, and the stated range ends below it.
By their numbers in this assay, from the lowest: compounds 3 and 1 (each within the scatter of the next); then compounds 4 and 2 (each within the scatter of the next).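

Replacing 3,3-dimethoxypropyl with isopropyl on the aromatic nitrogen changes the read-out in this assay by a number 29.3 percentage points higher from compound 1 to compound 4 (beyond the scatter) with nothing else in the molecule altered. For the compounds shown here, this pair is the first to isolate this position, and it shows that this substituent alone can shift the antiproliferative effect, with isopropyl the better of the two groups. No available measurement accounts for the step. The compounds shown leave open whether chain length or the oxygen atoms of the leaving group matter. A plain pentyl chain or a 3-hydroxypropyl chain on this nitrogen would bear on that question.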